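Extending the amine substituent of compound 3

The compounds below may be only part of what the source reports. "The series", "measured", "known", "first", "only" and "open" are said of these compounds alone.

Three secondary amines built on a shared core have been run in a functional assay on SW-620 cells (Homo sapiens) for inhibition, read by MTT assay, with a stated time of 72 h; on this read-out higher numbers stand for weaker inhibition and lower numbers for stronger inhibition. Compound 1 `COc1ccc(CNCc2c(OC)cc(Oc3cccc(Nc4ccccc4)c3)cc2OC)cc1` gives 6970 nM, compound 2 `COc1cc(Oc2cccc(Nc3ccccc3)c2)cc(OC)c1CNCc1ccccc1` gives 7490 nM, and compound 3 `CNCc1c(OC)cc(Oc2cccc(Nc3ccccc3)c2)cc1OC` gives 15000 nM. Compound 3 carries the highest number of the three: the step of a 2.0-fold higher number from compound 2 to compound 3 (0.30 log units; within the scatter) is within the scatter, while the step of a 2.2-fold higher number from compound 1 to compound 3 (0.33 log units; beyond the scatter) lies just beyond it. The unmeasured compound 4 `COc1cc(Oc2cccc(Nc3ccccc3)c2)cc(OC)c1CN[C@H](C)c1ccccc1` departs from compound 3 by 1-phenylethyl in place of methyl on an amine nitrogen. Among the measured compounds shown here, two measured steps bear on this move, both run in the opposite sense: a 2.0-fold higher number from compound 2 to compound 3 (0.30 log units; within the scatter) and a 2.2-fold higher number from compound 1 to compound 3 (0.33 log units; beyond the scatter). Both show that taking an aromatic group off the saturated chain carbon bound to the amine nitrogen raises the number modestly or not beyond the scatter. Putting such a group back in compound 4, now as 1-phenylethyl with a defined stereocentre, is therefore expected to lower the number by roughly the size of those steps, which would leave compound 4 close to compound 2 rather than far below it. For compound 4 the expected step is a 2.1-fold lower number from compound 3 to compound 4 (0.33 log units; beyond the scatter). Compound 4 is estimated at 7000 nM, within a range from 3000 nM to 16000 nM.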

Compound 4, half-maximal inhibitory concentration: 18700 nM
Estimate against measurement, compound 4: 2.7-fold (0.43 log units) below; the measured number lies above the stated range.
By their numbers in this assay, from the lowest: compounds 1, 2, 3 and 4 (each within the scatter of the next, the first and the last beyond it).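

In this assay, adding an aromatic ring to the amine substituent does not by itself separate a compound from the methyl analogue: 1-phenylethyl in place of methyl on the amine nitrogen gives a 1.2-fold higher number from compound 3 to compound 4 (0.10 log units; within the scatter), so compound 3 and compound 4 cannot be told apart on this read-out. The new information lies at the saturated chain carbon bound to the amine nitrogen and the aromatic carbon, where methyl in place of hydrogen gives a 2.5-fold higher number from compound 2 to compound 4 (0.40 log units; beyond the scatter), and the exchange of 4-methoxybenzyl for 1-phenylethyl gives a 2.7-fold higher number from compound 1 to compound 4 (0.43 log units; beyond the scatter), both modest but beyond the scatter, showing that this branched group does not retain the numbers of the unbranched benzyl compounds. No available evidence explains the effect of this branching.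

The compounds shown leave open whether the opposite configuration at the defined stereocentre of compound 4 would give a different number from that of compound 4. They also leave open how a longer chain between the amine nitrogen and the ring, such as 2-phenylethyl, would compare with the benzyl substituent of compound 2.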